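The source may report more compounds than this note shows. Statements on the series, on what has been measured and on what is new or still open speak of the compounds shown alone.

Measured so far:
- compound 1 `O=[N+]([O-])c1cc(-c2nc(-c3ccccc3)no2)cc(O)c1O`, inhibition 20.6%
- compound 2 `O=[N+]([O-])c1cc(-c2cc(-c3ccncc3)no2)cc(O)c1O`, inhibition 32.1%

In a functional assay on the whole organism (liver, strain NMRI) for inhibition, with Mus musculus as the target, with a stated time of 3 h, at a dose of 3 mg/kg by the oral route (on this read-out higher numbers stand for more inhibition at the one dose given (going by the name of the read-out) and lower numbers for less inhibition), compound 1 gives 20.6%. In this assay compound 2 gives 32.1%. Of the two numbers, compound 2 stands highest; its nearest neighbour is compound 1, whose number is lower by a gap beyond the usual scatter. Among the measured compounds shown here, the two measured compounds differ in more than one place, so no single step between them is known.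

Compound 3 `O=[N+]([O-])c1cc(-c2cc(-c3ccnc(F)c3)no2)cc(O)c1O` differs from compound 2 in one place only:
fluoro in place of hydrogen on an aromatic carbon

For the measured compounds named here, no measured pair shows this change, so there is nothing to set its direction or size. The expectation for the step from compound 2 to compound 3 is therefore no step beyond the scatter, with a number 2.1 percentage points lower from compound 2 to compound 3 (within the scatter) as the estimated change. On that basis compound 3 is estimated at 30%, within a range from 15% to 45%.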

Compound 3, a percentage reported as inhibition, in the whole organism at one dose (the size of the read-out at that dose, not a potency): 18.7%
For compound 3 the middle estimate is 11.3 percentage points above the measured one; the measured number falls inside the stated range.
By their numbers in this assay, from the lowest: compounds 3 and 1 (each within the scatter of the next); then compound 2.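

Among the compounds shown here, the first one-place step, pyridin-4-yl to 2-fluoropyridin-4-yl, gives a number 13.4 percentage points lower from compound 2 to compound 3 (beyond the scatter) in this assay. The aromatic carbon next to the ring nitrogen is therefore not indifferent to substitution: at the one dose given, fluoro in place of hydrogen there lowers inhibition, although this single pair sets no trend for other positions or groups. Nothing available here gives a reason for this drop.

Still open, going by these compounds, is whether the loss is specific to fluoro or would also follow from an amine, a methoxy or a methyl at the same carbon. On these data alone, it is also open whether fluoro on another carbon of the pyridine ring would give a step of the same direction and size.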